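Compound 4 Against Three Values Held at a Limit

This account rests on a few compounds, and the source may have more. Where it says the series, first, only, none or still open, it means among the compounds named here.

In an ADME assay on MDBK cells (Bos taurus) for cytotoxicity (on this read-out lower numbers stand for higher toxicity in this test and higher numbers for lower toxicity in this test), compound 3 `Clc1ccccc1Cn1ccc2nc(-c3ccccc3)nc-2c1` gives only a limit of > 100000 nM and no number. Compound 1 `c1ccc(Cn2ccc3nc(-c4ccccc4)nc-3c2)cc1` likewise stands at a limit of > 100000 nM in the same test. Compound 2 `COc1ccccc1Cn1ccc2nc(-c3ccccc3)nc-2c1` also stands at a limit of > 100000 nM and no more. Compound 4 `Brc1ccc(Cn2ccc3nc(-c4ccccc4)nc-3c2)cc1` differs from compound 3 by 4-bromophenyl in place of 2-chlorophenyl on a saturated chain carbon bound to an aromatic nitrogen and carries 4-bromophenyl in place of 2-chlorophenyl. For the measured compounds named here, three measured steps bear on this change: a step that the two limits leave unreadable from compound 1 to compound 2, a step that the two limits leave unreadable from compound 1 to compound 3 and a step that the two limits leave unreadable from compound 2 to compound 3, so none offers a size or direction. All three compounds sit at the limit of > 100000 nM in this assay, at which 3 of the 3 values shown sit, with nothing firmer. In this assay the expected outcome is a number no higher from compound 3 to compound 4 (the limit leaves the size open), with no change beyond the scatter anticipated. For compound 4 the estimate is 100000 nM, with an expected range of 50000 nM to 200000 nM around it.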

Compound 4, half-maximal cytotoxic concentration: 83000 nM
Compound 4: middle estimate off by 1.2-fold (0.08 log units), on the high side, within the range that was stated.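

In this assay, for the compounds shown here, compound 4 alone gives a number rather than a limit, so 4-bromophenyl on a saturated chain carbon bound to an aromatic nitrogen yields the only readable steps here: an at least 1.2-fold lower number from compound 3 to compound 4 (0.08 log units; that floor lies within the scatter), an at least 1.2-fold lower number from compound 2 to compound 4 (0.08 log units; that floor lies within the scatter) and an at least 1.2-fold lower number from compound 1 to compound 4 (0.08 log units; that floor lies within the scatter). Each is only a floor, so no change beyond the scatter is shown. The steps among compounds 1, 2 and 3 cannot be read, and every comparison still rests on a limit: the limit of > 100000 nM in this assay, at which 3 of the 4 values shown sit.

As far as these compounds go, how far compounds 1, 2 and 3 lie beyond their limits stays open. So does whether an amine or a carboxylic acid in this place would give a clearly lower number.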